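The source may report more compounds than this note shows. Statements on the series, on what has been measured and on what is new or still open speak of the compounds shown alone.

Measured in an ADME assay on S9 fraction from liver (Homo sapiens) for metabolic stability, with a stated time of 1 h; a lower number here means that less of the compound is left, a higher number that more of the compound is left:
- Compound 1 `N#Cc1cnc(NCc2ccccc2)cc1N[C@H]1CC[C@@H](O)CC1`: 45%
- Compound 2 `N#Cc1cnc(NCc2cncnc2-c2ccccc2)cc1N[C@H]1CC[C@@H](O)CC1`: 42%

Compound 2, at 42%, lies within the usual scatter of compound 1, at 45%, so these two numbers cannot be told apart. The next structure is compound 3 `COc1ncncc1CNc1cc(N[C@H]2CC[C@@H](O)CC2)c(C#N)cn1`, which has methoxy in place of phenyl on an aromatic carbon. For the measured compounds named here, no measured pair of compounds differs in only one place, so no direct precedent exists for this swap. With only compound 1 at 45% and compound 2 at 42% to go on, no step beyond the scatter is expected in this assay, in either direction. The estimated change is a number 3 percentage points higher from compound 2 to compound 3 (within the scatter). For compound 3 the expected value is 45%, with an estimated range of 27% to 63%.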

Compound 3, percent of the compound remaining: 88%
Estimate against measurement, compound 3: 43 percentage points below, outside the stated range (above it).
By their numbers in this assay, from the lowest: compounds 2 and 1 (each within the scatter of the next); then compound 3.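

In this assay, methoxy in place of phenyl on an aromatic carbon of the six-membered aromatic ring with 2 nitrogen gives a number 46 percentage points higher from compound 2 to compound 3 (beyond the scatter), so this position has a large bearing on the read-out. Measured against the plain phenyl of compound 1, the 4-methoxypyrimidin-5-yl group gives a number 43 percentage points higher from compound 1 to compound 3 (beyond the scatter), a step of similar size. The swap takes away a whole aromatic ring and brings in one hydrogen-bond acceptor, but nothing measured here shows why the number rises.

The compounds shown leave open whether the rise depends on methoxy itself or simply on phenyl leaving. A methyl group, an ethoxy group or an amine on the same carbon would help separate those two readings.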